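Removing the nitro group from compound 2

The source may hold more compounds than are shown below. What is called first, only, known or untested is meant among the compounds shown, and "the series" means these compounds.

Values in a functional assay on MCF7 cells (Homo sapiens) for cytotoxicity; on this read-out higher numbers stand for weaker inhibition and lower numbers for stronger inhibition:
- compound 1 `COc1ccc2nc(NC(=O)CCCCC(=O)NO)sc2c1`: 5.91 ug/mL
- compound 2 `O=C(CCCCC(=O)Nc1nc2ccc([N+](=O)[O-])cc2s1)NO`: > 30 ug/mL

Compound 2 stands at a limit of this assay: its entry of > 30 ug/mL is a limit and not a number. This is the situation described by the limit of > 30 ug/mL in this assay, at which 1 of the 2 values shown sits. Within the data shown here, compound 1 provides the only true number so far, at 5.91 ug/mL.

The next entry is compound 3 `O=C(CCCCC(=O)Nc1nc2ccccc2s1)NO`, which differs from compound 2 as follows: hydrogen in place of nitro on an aromatic carbon. In words, this is hydrogen in place of nitro on an aromatic carbon.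

Among the measured compounds shown here, one measured step bears on this change: an at least 5.0-fold higher number from compound 1 to compound 2 (0.70 log units; beyond the scatter). That step, nitro in place of methoxy on an aromatic carbon, lies beyond the scatter and gives only a minimum size. Here the nitro group leaves, so a move towards a lower number, meaning stronger inhibition, is expected. For the measured compounds named here, no measured compound shows hydrogen in this place, so the size remains uncertain.

The expected change is an at least 3.7-fold lower number from compound 2 to compound 3 (0.57 log units; beyond the scatter). For compound 3 the estimate is 8 ug/mL, with an expected range from 3 ug/mL to 25 ug/mL.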

Compound 3, half-maximal inhibitory concentration: 4.02 ug/mL
The estimate for compound 3 lay 2.0-fold (0.30 log units) above the measured number; the measured number falls inside the stated range.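

In this assay, hydrogen in place of nitro gives an at least 7.4-fold lower number from compound 2 to compound 3 (0.87 log units; beyond the scatter), so the weak result for nitro at this position now holds against hydrogen as well as against methoxy. Hydrogen in place of methoxy gives a 1.5-fold lower number from compound 1 to compound 3 (0.17 log units; within the scatter), so this assay does not separate methoxy from hydrogen at this position, and among the three compounds only compound 2, the nitro compound, stands apart. Compound 2 carries a limit and not a number, so its step to compound 3 gives only a minimum size: the limit of > 30 ug/mL in this assay, at which 1 of the 3 values shown sits.

From the compounds shown here alone, whether the weaker inhibition belongs to nitro alone or also appears with other groups at this position, such as an amine, a nitrile or a carboxylic acid, remains open, and three compounds are too few to support a trend across groups. Also open, going by these compounds, is whether the same order among nitro, methoxy and hydrogen would hold with a longer chain on the shared core, or in cells other than the ones used here.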